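This account rests on a few compounds, and the source may have more. Where it says the series, first, only, none or still open, it means among the compounds named here.

Measured so far:
compound 1 `O=C(COCc1ccccc1)N1CCN(c2ccc(F)cc2)CC1`, 1100 nM
compound 2 `O=C(COCc1ccccc1)N1CCN(c2ccc(Cl)cc2Cl)CC1`, 1000 nM
compound 3 `O=C(COCc1ccccc1)N1CCN(c2ccc(F)cc2Cl)CC1`, 270 nM

In a functional assay on HEK293 cells for positive allosteric modulation of metabotropic glutamate receptor 5 (Homo sapiens), read by FLIPR and calcium flux (a lower number here means that less compound is needed, a higher number that more compound is needed for the effect), compound 3 gives the lowest number of the three; the steps of a 4.1-fold lower number from compound 1 to compound 3 (0.61 log units; beyond the scatter) and a 3.7-fold lower number from compound 2 to compound 3 (0.57 log units; beyond the scatter) both lie beyond the scatter, whereas a 1.1-fold lower number from compound 1 to compound 2 (0.04 log units; within the scatter) does not. Compound 4 `O=C(COCc1ccccc1)N1CCN(c2cc(Cl)ccn2)CC1` is not yet measured. The change is 4-chloropyridin-2-yl in place of 2-chloro-4-fluorophenyl on an amine nitrogen in a ring. Going by the values given here, no measured step exchanges the carbon-only ring for one with a hetero atom, so none bears on this directly; the two steps into compound 3 show only that the halogens on this ring move the number modestly. Since the 2-chloro-4-fluorophenyl is lost, a rise back toward the region of compounds 1 and 2 is expected. Expected for compound 4 is therefore a step of a 3.3-fold higher number from compound 3 to compound 4 (0.52 log units; beyond the scatter), with wide uncertainty. For compound 4 the estimate is 900 nM, range 250 nM to 3500 nM.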

Compound 4, half-maximal effective concentration: 570 nM
Beside the measured number, compound 4's estimate is 1.6-fold (0.20 log units) above it, within the range that was stated.
By their numbers in this assay, from the lowest: compound 3; then compounds 4, 2 and 1 (each within the scatter of the next).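

A ring with a hetero atom is accepted at this position: 4-chloropyridin-2-yl stays in the region of the phenyl compounds, with a 1.8-fold lower number from compound 2 to compound 4 (0.24 log units; within the scatter) and a 1.9-fold lower number from compound 1 to compound 4 (0.29 log units; within the scatter) both within the scatter. Against 2-chloro-4-fluorophenyl, however, the exchange gives a 2.1-fold higher number from compound 3 to compound 4 (0.32 log units; beyond the scatter) and compound 3 remains the lowest of the four. No measurement on hand gives a reason for this step.

Compound 4 differs from compound 3 in both the ring nitrogen and the halogens, and the compounds shown do not separate the two. Also open, going by these compounds, is how a nitrile or a methoxy group would read in place of the chloro on the 4-chloropyridin-2-yl.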